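The source may report more compounds than this note shows. Statements on the series, on what has been measured and on what is new or still open speak of the compounds shown alone.

Measured so far:
- compound 1, `Cc1ccccc1Nc1nc(Nc2ccc(N3CCN(C)CC3)cc2)ncc1Cl`: 6510 nM
- compound 2, `CCN1CCN(c2ccc(Nc3ncc(Cl)c(Nc4ccccc4C)n3)cc2)CC1`: 970 nM
- compound 3, `CCc1ccc(Nc2nc(Nc3ccc(N4CCN(C)CC4)cn3)ncc2Cl)cc1`: 12100 nM

These three were measured in an ADME assay on L02 cells (Homo sapiens) for inhibition, read by CCK-8 assay, with a stated time of 48 h; on this read-out higher numbers stand for weaker inhibition of growth and lower numbers for stronger inhibition of growth. Compound 4, `CC(C)c1ccc(Nc2nc(Nc3ccc(N4CCN(C)CC4)cn3)ncc2Cl)cc1`, has not yet been measured in this assay.

Compound 1 and compound 2 differ by methyl in place of hydrogen on a saturated chain carbon bound to an amine nitrogen in a ring. This change gave a 6.7-fold lower number from compound 1 to compound 2 (0.83 log units; beyond the scatter). Compound 3 carries a different core than compound 1, and the difference between the two cores is not broken down here; their values in this assay lie within the usual scatter of each other, while compound 2 sits well apart from compound 3.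

Compound 4 differs from compound 3 by methyl in place of hydrogen on a saturated chain carbon bound to an aromatic carbon and a saturated chain carbon. Among the compounds with values here, this is the same kind of change as the one from compound 1 to compound 2, a methyl replacing a hydrogen, but the place differs: there the carbon was bound to an amine nitrogen in a ring, here it is bound to an aromatic carbon and a saturated chain carbon, and the core is also a different one. Because of a 6.7-fold lower number from compound 1 to compound 2 (0.83 log units; beyond the scatter), a move toward stronger inhibition is expected, yet with the place and core changed a smaller step, a 1.7-fold lower number from compound 3 to compound 4 (0.24 log units; within the scatter), is the estimate here. Compound 4 is therefore expected to give about 7000 nM in this assay.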

Compound 4, concentration for 50% growth inhibition: 13700 nM
Beside the measured number, compound 4's estimate is 2.0-fold (0.29 log units) below it; low and high end bracket the measured number.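

In this assay, replacing a hydrogen with a methyl, which turns ethyl into isopropyl, gave a 1.1-fold higher number from compound 3 to compound 4 (0.05 log units; within the scatter) and so made no clear difference on this core. Set beside the earlier step, the same kind of change did not keep its size from one core to the other: the same change on two cores in this assay, a 6.7-fold lower number (0.83 log units; beyond the scatter) from compound 1 to compound 2 and a 1.1-fold higher number (0.05 log units; within the scatter) from compound 3 to compound 4, 7.6-fold (0.88 log units) apart, beyond the scatter of two such steps

This does not show whether the core or the place of the methyl accounts for the gap: the two steps differ in both, and each rests on a single pair of compounds.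

The compounds shown leave open whether a methyl added on the saturated chain carbon bound to an amine nitrogen in a ring would give a clear step on the core of compound 3. They also leave open how that core responds when the isopropyl of compound 4 gives way to a tert-butyl, a longer chain or an amine.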